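Removing the 4-chlorophenyl group from compound 2

This account rests on a few compounds, and the source may have more. Where it says the series, first, only, none or still open, it means among the compounds named here.

Compound 1 `Cn1cc(C2=C(c3nn(CCCn4cncn4)c4ncccc34)C(=O)N(c3ccccc3)C2=O)c2ccccc21` and compound 2 `Cn1cc(C2=C(c3nn(CCCN4CCCCC4)c4ncccc34)C(=O)N(c3ccc(Cl)cc3)C2=O)c2ccccc21` were both examined in a functional assay on KB cells (Homo sapiens) for antiproliferative activity, read by MTT assay, with a stated time of 48 h; on this read-out lower numbers stand for stronger inhibition and higher numbers for weaker inhibition. In this test, compound 1 gives > 100000 nM, which is a limit of the assay and not a number. Compound 2 gives > 100000 nM, which is also a limit. Compound 2 therefore stands at the limit of > 100000 nM in this assay, at which 2 of the 2 values shown sit. No order between the two compounds can be read from these results.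

Compound 3 `Cn1cc(C2=C(c3nn(CCCN4CCCCC4)c4ncccc34)C(=O)NC2=O)c2ccccc21` differs from compound 2 in one place: hydrogen in place of 4-chlorophenyl on an amide-type nitrogen in a ring. For the measured compounds named here, no measured pair shows what this change does, so any expectation is uncertain. A visible change can only run toward stronger inhibition because compound 2 has only the limit > 100000 nM. The expected step of an at least 5.0-fold lower number from compound 2 to compound 3 (0.69 log units; beyond the scatter) is modest and points toward stronger inhibition, although another limit reading remains quite possible. For compound 3 the estimated value is 20000 nM, with an expected range from 3000 nM to 100000 nM.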

Compound 3, half-maximal inhibitory concentration: 98000 nM
For compound 3 the middle estimate is 4.9-fold (0.69 log units) below the measured one, within the range that was stated.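

In this assay, for the compounds shown here, compound 3 gives 98000 nM, a true reading and the first number in this set. The two earlier compounds gave only limits. Read as a step, the exchange of 4-chlorophenyl for hydrogen on this amide-type nitrogen is an at least 1.0-fold lower number from compound 2 to compound 3 (0.00 log units; that floor lies within the scatter), so no gain beyond the usual scatter is shown, and the real size of the change stays unknown. Compound 2 has only a limit and not a number, so the result shows that the 4-chlorophenyl group is not needed for a measurable reading, while all three compounds stay at the weak end of the scale: the limit of > 100000 nM in this assay, at which 2 of the 3 values shown sit.

The compounds shown leave open whether another group on this nitrogen, such as a methyl, a benzyl or a short chain ending in a carboxylic acid, would bring a clear move toward stronger inhibition. The chlorine also cannot be judged on its own, as no pair shown differs only in that atom.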